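A few compounds are considered here, and "the series" means these few. Any claim that something is new, unique, unknown or untested is made for them only; others in the source may bear on it.

The measured compounds:
Compound 1 `Cc1cc(C)c(-c2ncc[nH]2)cc1NC(=O)c1ccc(OCc2ccccn2)cc1` gives 2000 nM in a physicochemical assay for solubility, at pH 7.4; on this read-out lower numbers stand for lower solubility and higher numbers for higher solubility.
Compound 2 `Cc1cc(C)c(-c2c[nH]nc2C)cc1NC(=O)c1ccc(OCc2ccccn2)cc1` gives 33000 nM in this assay.
Compound 3 `Cc1cc(C)c(-c2ccccn2)cc1NC(=O)c1ccc(OCc2ccccn2)cc1` reaches only a limit of this assay, < 1000 nM.

Compound 3 therefore sits at the limit of < 1000 nM in this assay, at which 1 of the 3 values shown sits, so only a ceiling is known for it, not a number. The two measured steps that lead into compound 3 both run downward: an at least 2.0-fold lower number from compound 1 to compound 3 (0.30 log units; that floor lies within the scatter), and an at least 33-fold lower number from compound 2 to compound 3 (1.51 log units; beyond the scatter). The first of these is small enough to fall inside the usual scatter, the second is large.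

Compound 4 `Cc1cc(C)c(-c2cccnc2)cc1NC(=O)c1ccc(OCc2ccccn2)cc1` has the same atoms as compound 3, joined differently: pyridin-3-yl in place of pyridin-2-yl on an aromatic carbon. For the measured compounds named here, the measured steps all concern a change of the whole ring attached at that carbon, and none of them involves pyridin-3-yl, so there is no direct precedent for this rearrangement. Because an at least 2.0-fold lower number from compound 1 to compound 3 (0.30 log units; that floor lies within the scatter) and an at least 33-fold lower number from compound 2 to compound 3 (1.51 log units; beyond the scatter) both point toward the floor, the expectation is that compound 4 also sits low, and the step expected is an at least 1.2-fold higher number from compound 3 to compound 4 (0.07 log units; that floor lies within the scatter), not beyond the scatter. The estimate for compound 4 in this assay is 1200 nM, with a range from 400 nM to 4000 nM.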

Compound 4, solubility: 9000 nM
Beside the measured number, compound 4's estimate is 7.5-fold (0.88 log units) below it, and the stated range ends below it.
By their numbers in this assay, from the lowest: compound 1; then compound 4; then compound 2. At a limit, below all of these: compound 3.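

Joining the same ring differently is enough to change the result at this position on the core: with no atom gained or lost, pyridin-3-yl in place of pyridin-2-yl gives an at least 9.0-fold higher number from compound 3 to compound 4 (0.95 log units; beyond the scatter). As far as these compounds go, the true size of that step is unknown and could be larger, because compound 3 gives only a limit and not a number: the limit of < 1000 nM in this assay, at which 1 of the 4 values shown sits. The earlier compounds shown here could have suggested that a pyridine ring at this carbon sits lowest in this assay, but the new result rules that out, with a 4.5-fold higher number from compound 1 to compound 4 (0.65 log units; beyond the scatter) and a 3.7-fold lower number from compound 2 to compound 4 (0.56 log units; beyond the scatter), so compound 4 falls between the imidazole and methylpyrazole compounds, while compound 3 remains the lowest.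

Still open, from the compounds shown here alone, is where pyridin-4-yl, another way of attaching this ring, would fall, and whether an amine or a carboxylic acid on the pyridin-3-yl ring would raise the number further. Also open, going by these compounds, are how far compound 3 lies under its limit and why the way the ring is joined makes a difference of this size.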